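Methyl to Chloro on the Anilide Ring

The source may report more compounds than this note shows. Statements on the series, on what has been measured and on what is new or still open speak of the compounds shown alone.

Compound 1 `COc1cccc(NC(=O)c2ccc3cccc(O)c3n2)c1` and compound 2 `Cc1ccc(NC(=O)c2ccc3cccc(O)c3n2)cc1` share one core and differ only in the substituent on the anilide ring. In an ADME assay on THP-1 cells (Homo sapiens) for cytotoxicity, read by WST assay, with a stated time of 24 h (on this read-out higher numbers stand for weaker inhibition and lower numbers for stronger inhibition), compound 1 gives > 30000 nM, which is a limit of the assay and not a number. In this assay compound 2 gives > 30000 nM, also a limit. Compound 2 thus stands at the limit of > 30000 nM in this assay, at which 2 of the 2 values shown sit, together with compound 1, and nothing in the shown numbers separates the two. Compound 3 `O=C(Nc1ccc(Cl)cc1)c1ccc2cccc(O)c2n1` has not yet been measured in this assay. It differs from compound 2 by chloro in place of methyl on an aromatic carbon. For the measured compounds named here, with no measured step between the two, the step from compound 2 to compound 3 is expected to be a step that the limit leaves unreadable from compound 2 to compound 3, none beyond the scatter in this assay. Compound 3 is therefore estimated at 40000 nM, within a range of 15000 nM to 120000 nM, most likely reported again as a limit.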

Compound 3, half-maximal inhibitory concentration: > 30000 nM
Compound 3: no number, only a limit; the forecaster's own chance of this, stated with the estimate: 80%; the middle value is on the limit's open side.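

In this assay compound 3 gives > 30000 nM as a limit and not a number, so no step can be read between compound 2 and compound 3. The compounds shown leave open how compound 1, compound 2 and compound 3 rank against one another: the limit of > 30000 nM in this assay, at which 3 of the 3 values shown sit.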